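The source may hold more compounds than are shown below. What is called first, only, known or untested is meant among the compounds shown, and "the series" means these compounds.

Measured in a functional assay on A-375 cells (Homo sapiens) for antiproliferative activity, with a stated time of 72 h; on this read-out lower numbers stand for stronger inhibition and higher numbers for weaker inhibition:
- compound 1 `C=C1C=CC(=O)[C@@H]2[C@H](Cc3ccc(OCOC)c(F)c3)CC[C@H]12`: 40 nM
- compound 2 `C=C1C=CC(=O)[C@@H]2[C@H](Cc3ccc(F)c(F)c3)CC[C@H]12`: 222 nM

For the measured compounds named here, of these two numbers, compound 2 stands highest at 222 nM, and its only neighbour is compound 1 at 40 nM. Compound 3 `C=C1C=CC(=O)[C@@H]2[C@H](Cc3ccc(OC)c(F)c3)CC[C@H]12` differs from compound 2 in one place: methoxy in place of fluoro on an aromatic carbon. This is methoxy in place of fluoro on an aromatic carbon, ortho to a fluoro group and para to a large group.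

Going by the values given here, one measured step bears on this change, at the same carbon: a 5.6-fold higher number from compound 1 to compound 2 (0.74 log units; beyond the scatter), with fluoro in place of methoxymethoxy. It was modest but beyond the scatter. The new step runs the opposite way, from fluoro back to an ether, though to methoxy rather than methoxymethoxy. A lower number in this assay is therefore expected, with most of that modest step recovered. The estimated step is a 3.0-fold lower number from compound 2 to compound 3 (0.47 log units; beyond the scatter). For compound 3 the estimate is 75 nM, with an expected range of 30 nM to 190 nM.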

Compound 3, half-maximal inhibitory concentration: 1.68 nM
The estimate for compound 3 lay 45-fold (1.65 log units) above the measured number, and the stated range ends above it.
By their numbers in this assay, from the lowest: compound 3; then compound 1; then compound 2.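

In this assay, for the compounds shown here, the ether at this aromatic carbon matters far more than the earlier pair showed: methoxy in place of fluoro gives a 130-fold lower number from compound 2 to compound 3 (2.12 log units; beyond the scatter) and is a large step, where the only earlier step at this carbon was modest. The two ethers also do not behave alike, as the change from methoxymethoxy to methoxy gives a 24-fold lower number from compound 1 to compound 3 (1.38 log units; beyond the scatter) and is large as well. So the presence of an ether at this carbon does not alone set the number, and compound 3, with methoxy, stands lowest of the three. No evidence is available on why these steps are so large.

On these data alone, whether ethoxy, a longer chain, hydroxy or an amine at this carbon would hold the low number stays open. This carbon is also ortho to a fluoro group in all three compounds, so what that fluoro group adds cannot be told.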